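A few compounds are considered here, and "the series" means these few. Any claim that something is new, unique, unknown or untested is made for them only; others in the source may bear on it.

Measured compounds in this series:

compound 1, `COC[C@H]1CN(c2ccc(-n3cc(-c4ccccn4)cn3)c(F)c2)C(=O)O1`, 2.18 in a physicochemical assay for lipophilicity, read by HPLC, measured as octanol-water partition; on this read-out higher numbers stand for higher lipophilicity and lower numbers for lower lipophilicity
compound 2, `O=C1O[C@@H](Cn2ccnc2)CN1c1ccc(-n2cc(-c3ccccn3)cn2)c(F)c1`, 1.73 in this assay
compound 3, `CCNC(=O)NC[C@H]1CN(c2ccc(-n3cc(-c4ccccn4)cn3)c(F)c2)C(=O)O1`, 2.45 in this assay

Compound 3 stands highest of the three numbers; its gap to compound 1 is small, a number 0.27 log units higher from compound 1 to compound 3 (within the scatter), while its gap to compound 2 is clearer, a number 0.72 log units higher from compound 2 to compound 3 (beyond the scatter). The remaining step, a number 0.45 log units lower from compound 1 to compound 2 (beyond the scatter), also concerns only the group on the saturated chain carbon.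

Compound 4, `O=C(NC[C@H]1CN(c2ccc(-n3cc(-c4ccccn4)cn3)c(F)c2)C(=O)O1)C(F)F`, differs from compound 3 at another place: difluoromethyl in place of ethylamino on a carbonyl carbon. Going by the values given here, none of the three measured steps touches the carbonyl carbon, so no step bears directly on this change. The steps that introduce the ethylcarbamoyl group, from compound 1 and from compound 2 into compound 3, were modest or within the scatter, and the present swap keeps the carbonyl and its amide-type nitrogen in place. The expectation is therefore a step of no more than the scatter in this assay, a number 0.05 log units higher from compound 3 to compound 4 (within the scatter). For compound 4 the estimated value in this assay is 2.5, with a range from 2.1 to 2.9.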

Compound 4, partition coefficient: 1.9
Estimate against measurement, compound 4: 0.60 log units above, outside the stated range (below it).
By their numbers in this assay, from the lowest: compounds 2, 4, 1 and 3 (each within the scatter of the next, the first and the last beyond it).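

In this assay, the carbonyl carbon proves to be a place where a change registers beyond the scatter: difluoromethyl in place of ethylamino gives a clear step (a number 0.55 log units lower from compound 3 to compound 4 (beyond the scatter)), with the hydrogen-bond donor counted in ethylamino gone. The ((difluoromethyl)carbonyl)amino group nevertheless stays within the scatter of the two other groups on the saturated chain carbon (a number 0.17 log units higher from compound 2 to compound 4 (within the scatter); a number 0.28 log units lower from compound 1 to compound 4 (within the scatter)), so compound 3 alone stands clear of it. No measurement shown accounts for the step on the carbonyl carbon.

As far as these compounds go, the swap changes the nitrogen and the fluorine together, so their separate shares stay open. An ethyl group, a trifluoromethyl group or a longer amine chain on the same carbonyl carbon would bear on that question.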